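Cyclopropyl on a Series Held at the Assay Limit

The source may hold more compounds than are shown below. What is called first, only, known or untested is meant among the compounds shown, and "the series" means these compounds.

In an ADME assay on cells (Peritoneal macrophage cell, Mus musculus) for cytotoxicity, read by fluorescence and resazurin assay, with a stated time of 3 days (on this read-out higher numbers stand for lower toxicity in this test and lower numbers for higher toxicity in this test), three compounds have been tested so far, and none gives a number. Compound 1 `CC(C)Oc1cc(C(=O)Nc2cc(-c3ccccn3)n[nH]2)cc(C(=O)N2CCCC2)c1` reports only a limit, > 40300 nM. Compound 2 `COc1ccc(C(=O)Nc2cc(-c3ccccn3)n[nH]2)cc1` also reports only a limit, > 40300 nM, so it stands without a number of its own. Compound 4 `COc1ccc(C(=O)Nc2[nH]nc(-c3ccccn3)c2C2CC2)cc1` differs from compound 2 by having cyclopropyl in place of hydrogen on an aromatic carbon. Compound 3 `O=C(NCc1ccccc1)Nc1[nH]nc(-c2ccccn2)c1Cl` also lacks a hydrogen on that aromatic carbon, and it reports only a limit, > 64000 nM. Among the compounds with values here, no measured pair shows this change alone, so no step beyond the scatter is expected. The expected step is an at least 1.1-fold lower number from compound 2 to compound 4 (0.06 log units; that floor lies within the scatter). For compound 4 the estimated value is 35000 nM, with an expected range of 14000 nM to 70000 nM.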

Compound 4, half-maximal cytotoxic concentration: > 64000 nM
Compound 4 ended at the assay's limit (the forecaster's own chance of this, stated with the estimate: 65%); at least 1.8-fold (0.26 log units) between middle value and limit.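

Compound 2 and compound 4 both report only limits in this assay, and no step can be read between them. The compounds shown leave open whether cyclopropyl in place of hydrogen on an aromatic carbon changes this read-out at all.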